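Replacing 2-hydroxyphenyl with 6-methylpyridin-3-yl: clearance notes

The source may hold more compounds than are shown below. What is called first, only, known or untested is meant among the compounds shown, and "the series" means these compounds.

Measured in an ADME assay (liver) for metabolic stability, with Liver microsome (Rattus norvegicus) as the target, using microsomes and NADPH, with a stated time of 30 min, tested at 1 uM (on this read-out higher numbers stand for fast clearance and lower numbers for slow clearance), so far
compound 1 `Nc1ccc(S(=O)(=O)N2CCN(c3ncc(C(O)(C(F)(F)F)C(F)(F)F)cc3Br)CC2)cn1` gives 32 mL.min-1.g-1
compound 2 `CC(C)n1cc(-c2cc(C(O)(C(F)(F)F)C(F)(F)F)cnc2N2CCN(S(=O)(=O)c3ccc(N)nc3)CC2)cn1` gives 198 mL.min-1.g-1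
compound 3 `Nc1ccc(S(=O)(=O)N2CCN(c3ncc(C(O)(C(F)(F)F)C(F)(F)F)cc3-c3ccccc3O)CC2)cn1` gives 125 mL.min-1.g-1
Still without a number is compound 4 `Cc1ccc(-c2cc(C(O)(C(F)(F)F)C(F)(F)F)cnc2N2CCN(S(=O)(=O)c3ccc(N)nc3)CC2)cn1` in this series.

On these three numbers compound 3 belongs to the high end. The nearest gap is a 1.6-fold lower number from compound 2 to compound 3 (0.20 log units; within the scatter) and the furthest is a 3.9-fold higher number from compound 1 to compound 3 (0.59 log units; beyond the scatter) in this set.

The change under review is 6-methylpyridin-3-yl in place of 2-hydroxyphenyl on an aromatic carbon and amounts to 6-methylpyridin-3-yl in place of 2-hydroxyphenyl on an aromatic carbon, ortho to a large group.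

Among the compounds with values here, the closest precedent is the exchange of one ring for another, which gave a 1.6-fold lower number from compound 2 to compound 3 (0.20 log units; within the scatter) and so stayed small. Going from bromo to a ring gave modest steps such as a 6.2-fold higher number from compound 1 to compound 2 (0.79 log units; beyond the scatter) but compound 4 keeps a ring at that place, so that step bears on it only loosely. No step beyond the scatter is therefore expected in this assay for this change. The estimated step is a 1.1-fold lower number from compound 3 to compound 4 (0.06 log units; within the scatter) and no more than that is expected. For compound 4 the expected value is 110 mL.min-1.g-1 with an estimated range from 50 mL.min-1.g-1 to 230 mL.min-1.g-1 on this read-out.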

Compound 4, intrinsic clearance in microsomes: 182 mL.min-1.g-1
Beside the measured number, compound 4's estimate is 1.7-fold (0.22 log units) below it; the measured number falls inside the stated range.
By their numbers in this assay, from the lowest: compound 1; then compounds 3, 4 and 2 (each within the scatter of the next).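

In this assay, 6-methylpyridin-3-yl in place of 2-hydroxyphenyl gives a 1.5-fold higher number from compound 3 to compound 4 (0.16 log units; within the scatter), so at this place, ortho to a large group, a ring with 0 hydrogen-bond donors reads the same, within the scatter, as the ring with 1 donor. Against the five-membered 1-isopropyl-1H-pyrazol-4-yl ring the result is a 1.1-fold lower number from compound 2 to compound 4 (0.04 log units; within the scatter), which places compounds 2, 3 and 4 together within the scatter. Bromo alone stands apart in this set, as a third ring replacement gives a 5.7-fold higher number from compound 1 to compound 4 (0.75 log units; beyond the scatter).

Nothing available accounts for this grouping of the ring compounds. Open, as far as these compounds go, is whether an amine, a carboxylic acid or a longer chain at this place would read nearer compound 1 or nearer the ring compounds.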